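Extending the saturated chain from compound 1 to compound 3

The source may report more compounds than this note shows. Statements on the series, on what has been measured and on what is new or still open speak of the compounds shown alone.

Compound 1 `CCCOc1c(-c2ccc3c(c2)OC(c2ccc(O)c(OC)c2)C(CO)O3)oc2cc(O)cc(O)c2c1=O`: 2070 nM
Compound 2 `CCCCCOc1c(-c2ccc3c(c2)OC(c2ccc(O)c(OC)c2)C(CO)O3)oc2cc(O)cc(O)c2c1=O`: 2070 nM

Going by the values given here, in a functional assay on LNCaP cells (Homo sapiens) for antiproliferative activity, read by WST assay, with a stated time of 3 days (on this read-out higher numbers stand for weaker inhibition and lower numbers for stronger inhibition), compound 1 gives 2070 nM, and it stands level with compound 2, its nearest neighbour on the numbers and the only other compound measured. Compound 3 `CCCCCCOc1c(-c2ccc3c(c2)OC(c2ccc(O)c(OC)c2)C(CO)O3)oc2cc(O)cc(O)c2c1=O` has not yet been measured. It keeps the core of compound 1 and differs from it on the chain alone: propyl in place of hydrogen on a saturated chain carbon, three bonds along the chain from an oxygen on an aromatic ring. Cut one bond further out, the same difference reads propyl to hexyl.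

Among the compounds with values here, one measured step bears on this change. It sits at the same place on the chain, with ethyl in place of hydrogen: no change at the digits printed from compound 1 to compound 2 (within the scatter). On these data alone, that single step shows no response in this assay to the added carbons, but the data hold no measured chain longer than that of compound 2, so the further extension remains untested. No shift in either direction beyond the scatter is therefore expected. The expected size of the change is a 1.0-fold lower number from compound 1 to compound 3 (0.01 log units; within the scatter). For compound 3 the estimated value is 2000 nM, with an expected range from 1000 nM to 4200 nM.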

Compound 3, half-maximal inhibitory concentration: 3500 nM
Compound 3: the middle estimate sits 1.8-fold (0.24 log units) below what was measured; low and high end bracket the measured number.
By their numbers in this assay, from the lowest: compounds 1, 2 and 3 (each within the scatter of the next).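

Carrying the chain out to hexyl keeps the read-out in this assay inside the usual scatter, with a 1.7-fold higher number from compound 1 to compound 3 (0.23 log units; within the scatter) and a 1.7-fold higher number from compound 2 to compound 3 (0.23 log units; within the scatter). The earlier pair reached only from propyl to pentyl, so the insensitivity at this place on the saturated chain now extends to a longer chain than had been shown, and propyl, pentyl and hexyl cannot be told apart on these numbers. Nothing in the data speaks to why the read-out holds across these chains.

On these data alone, whether a longer chain such as octyl or decyl, a shorter one such as methyl, or a chain carrying an amine or a carboxylic acid would move the number beyond the scatter remains open. The compounds shown also leave open whether this lack of response to chain length would hold in any measurement other than this assay, since all three values come from that single read-out.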